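The compounds below may be only part of what the source reports. "The series", "measured", "known", "first", "only" and "open" are said of these compounds alone.

In an in vitro ADME assay on microsomes from liver (Mus musculus) for pharmacokinetics, read by LC-MS, with a stated time of 10 min, tested at 1 uM (on this read-out lower numbers stand for slow clearance and higher numbers for fast clearance), compound 1 (`CN1C[C@H](C(=O)Nc2cccc(Cl)c2)[C@@H](c2ccc(/C=C/C(=O)Nc3ccccc3N)cc2)C1`) gives 58 mL/min/kg and compound 2 (`Cc1cccc(NC(=O)[C@H]2CN(C)C[C@@H]2c2ccc(/C=C/C(=O)Nc3ccccc3N)cc2)c1`) gives 74 mL/min/kg. For the measured compounds named here, these two values lie within the scatter of each other, so compound 2 cannot be separated from the only other compound measured. Compound 3 (`Cc1cc(NC(=O)[C@H]2CN(C)C[C@@H]2c2ccc(/C=C/C(=O)Nc3ccccc3N)cc2)ccc1Cl`) derives from compound 2 by placing chloro in place of hydrogen on an aromatic carbon. Going by the values given here, the single measured step that bears on this is a 1.3-fold higher number from compound 1 to compound 2 (0.11 log units; within the scatter), in which a methyl group replaces the chloro group. That step involves chloro on the same kind of ring, but it is not the same change, so it offers only a loose guide. Going by its small size, no change beyond the scatter is expected in this assay, and the expected step is a 1.1-fold lower number from compound 2 to compound 3 (0.04 log units; within the scatter). For compound 3 the estimated clearance is 68 mL/min/kg, with an expected range from 38 mL/min/kg to 110 mL/min/kg.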

Compound 3, clearance: 65 mL/min/kg
Beside the measured number, compound 3's estimate is 1.0-fold (0.02 log units) above it; low and high end bracket the measured number.
By their numbers in this assay, from the lowest: compounds 1, 3 and 2 (each within the scatter of the next).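

In this assay, chloro in place of hydrogen on the aromatic carbon ortho to a methyl group and para to a large group gives a 1.1-fold lower number from compound 2 to compound 3 (0.06 log units; within the scatter) and so does not separate the two compounds. For the compounds shown here, this is the first direct reading at this position, and it shows that the 3-methylphenyl group can become 4-chloro-3-methylphenyl with no change in clearance beyond the scatter. The larger change, 4-chloro-3-methylphenyl in place of 3-chlorophenyl on the amide-type nitrogen, gives a 1.1-fold higher number from compound 1 to compound 3 (0.05 log units; within the scatter) and likewise stays within the scatter, so the three compounds cannot be told apart on this read-out. Nothing shown here offers an explanation for these numbers.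

The compounds shown leave open whether an amine, a carboxylic acid or a methoxy group at this position would move clearance beyond the scatter. They also leave open whether chloro here would read the same without the neighbouring methyl group.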